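Working notes: a methyl step from compound 1

The compounds below may be only part of what the source reports. "The series", "measured", "known", "first", "only" and "open" are said of these compounds alone.

Measured so far in a functional assay on the whole organism with Mus musculus as the target (on this read-out lower numbers stand for an effect already at smaller amounts and higher numbers for an effect only at larger amounts of compound), are these compounds:
- compound 1 `OC1CCN(c2ccc(-c3ccccc3)nn2)CC1` gives 83 mg/kg
- compound 2 `OC1CCN(c2ccc(-c3cc(Cl)ccc3Cl)nn2)CC1` gives 131 mg/kg

Going by the values given here, compound 1 stands within the usual scatter of compound 2, the only other number available, so the pair sets no order. Compound 3 `Cc1ccccc1-c1ccc(N2CCC(O)CC2)nn1` has not yet been measured in this assay and carries a single change from compound 1. That change, methyl in place of hydrogen on an aromatic carbon, ortho to a large group, is counted as methyl in place of hydrogen on an aromatic carbon and is the whole difference.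

Among the compounds with values here, no measured pair isolates this change, so the series offers no direct guide to its size. The two numbers in hand, compound 1 at 83 mg/kg and compound 2 at 131 mg/kg, lie close together, and this gives little reason to expect a large move. No shift beyond the scatter is expected, with only a slight lean towards a lower number. The estimate corresponds to an expected 1.5-fold lower number from compound 1 to compound 3 (0.18 log units; within the scatter) and remains uncertain in direction. For compound 3 the expected value is 55 mg/kg with an estimated range from 15 mg/kg to 140 mg/kg in this whole-animal setting.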

Compound 3, dose for half-maximal effect: 40 mg/kg
Estimate against measurement, compound 3: 1.4-fold (0.14 log units) above; low and high end bracket the measured number.
By their numbers in this assay, from the lowest: compound 3; then compounds 1 and 2 (each within the scatter of the next).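

Going by these compounds alone, this is the first step that isolates a single change: in this assay methyl in place of hydrogen on an aromatic carbon, ortho to a large group, gives a 2.1-fold lower number from compound 1 to compound 3 (0.32 log units; beyond the scatter) and so moves the number beyond the usual scatter. The earlier compounds shown here differ from each other in more than one place and could not show whether this position responds at all; it now does, towards a lower number, although the step is modest and rests on one pair. Nothing in hand bears on why the number moves.

Going by these compounds, whether the response at this position depends on the size or nature of the group stays open, since ethyl, methoxy, chlorine, an amine or a carboxylic acid at the same place would each be needed to tell a trend from a single point. On these data alone, it is also open whether methyl on the other aromatic carbons of this ring gives a similar step, and whether the same change carries over to the ring as it stands in compound 2.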